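Allyloxy versus free hydroxy on the pyridyl ketone core

The source may hold more compounds than are shown below. What is called first, only, known or untested is meant among the compounds shown, and "the series" means these compounds.

Measured so far:
compound 1 `C=CCOc1ccc(F)cc1C(=O)c1cccnc1` — in a functional assay on PC-3 cells (Homo sapiens) for cytotoxicity, read by sulforhodamine B assay, with a stated time of 48 h (a lower number here means a stronger inhibitor, a higher number a weaker inhibitor), compound 1 gives > 100000 nM, which is a limit of the assay.
compound 2 `C=CCOc1cc(Br)ccc1C(=O)c1cccnc1` — in this assay compound 2 gives > 100000 nM, again a limit rather than a number.

Compound 1 therefore stands at the limit of this assay, and no ranking against compound 2 is possible, since both sit at the same limit (the limit of > 100000 nM in this assay, at which 2 of the 2 values shown sit). The next compound, compound 3 `O=C(c1cccnc1)c1cc(F)ccc1O`, differs from compound 1 by hydrogen in place of allyl on an oxygen on an aromatic ring; read one bond further out, allyloxy becomes hydroxy. Within the data shown here, with both measured compounds at the limit, no step within the pair can be sized, and no direction can be read from them. The expectation for compound 3 is a step from compound 1 that stays within the scatter, a step that the limit leaves unreadable from compound 1 to compound 3, most likely ending again at the limit. Compound 3 is thus estimated at 150000 nM in this assay, with a range from 40000 nM to 600000 nM.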

Compound 3, half-maximal inhibitory concentration: 11800 nM
Estimate against measurement, compound 3: 13-fold (1.10 log units) above; the measured number lies below the stated range.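

In this assay, among these compounds, allyloxy to hydroxy on the aromatic ring gives an at least 8.4-fold lower number from compound 1 to compound 3 (0.92 log units; beyond the scatter), the first step that can be sized. Among the compounds shown here, compound 3 gives 11800 nM, the first measured number. The group on this oxygen therefore decides whether the series leaves the limit at all, at least with the fluorine-bearing compounds shown. Compound 1 stands at a limit, so the true size of the step has a lower bound and no upper one: the limit of > 100000 nM in this assay, at which 2 of the 3 values shown sit.

Still open, as far as these compounds go, is whether compound 2, with bromine in place of fluorine and at a different place on the ring, would follow the same change from allyloxy to hydroxy. Also open, from the compounds shown here alone, is whether a small ether such as methoxy, or an amine in place of the hydroxy, would hold the value of compound 3 or fall back to the limit.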